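A few compounds are considered here, and "the series" means these few. Any claim that something is new, unique, unknown or untested is made for them only; others in the source may bear on it.

Measured compounds:
compound 1 `N#Cc1nc(Nc2ccc([N+](=O)[O-])cc2)nc(N2CCNCC2)n1`, 23 nM
compound 2 `Cc1cccc(CNc2nc(C#N)nc(NC3CCCCC3)n2)c1`, 23 nM

Compound 2 stands level with compound 1 in an assay on isolated protein for inhibition of cathepsin S (Homo sapiens), with a stated time of 30 min; a higher number here means a weaker inhibitor, a lower number a stronger inhibitor: the two values differ by nothing beyond the scatter at the digits shown, so neither can be called the stronger inhibitor. The step to compound 3 `N#Cc1ccc(Nc2nc(C#N)nc(NC3CCCCC3)n2)cc1` is 4-cyanophenyl in place of 3-methylbenzyl on a nitrogen on an aromatic ring. Within the data shown here, no step between measured compounds shows what this exchange does. Compound 1, which also carries an aromatic group directly on an amine nitrogen of the shared core, gives 23 nM in this assay, so an aromatic group at an amine of this core is compatible with potency of this order. Compound 3 is therefore expected to remain close to compound 2, with an expected step of a 1.1-fold higher number from compound 2 to compound 3 (0.04 log units; within the scatter) in this assay, none beyond the scatter. The estimate for compound 3 is 25 nM, with a range from 8 nM to 80 nM.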

Compound 3, half-maximal inhibitory concentration: 23 nM
Beside the measured number, compound 3's estimate is 1.1-fold (0.04 log units) above it; low and high end bracket the measured number.
By their numbers in this assay, from the lowest: compounds 1, 2 and 3 (each within the scatter of the next).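

In this assay, replacing 3-methylbenzyl with 4-cyanophenyl on a nitrogen on an aromatic ring gives no change at the digits printed from compound 2 to compound 3 (within the scatter), the only direct reading of this position among the compounds shown. At this position, therefore, the two groups cannot be told apart in this assay, although each has 8 heavy atoms and one six-membered aromatic ring of carbon only, and only 4-cyanophenyl has a triple bond and a hydrogen-bond acceptor. Nothing in the data shown bears on why the two groups read alike.

On these data alone, whether a phenyl ring carrying a carboxylic acid in place of the nitrile would stay at this level remains open. So does whether a butyl chain, with no ring at all, would be tolerated on this nitrogen.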